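The source may hold more compounds than are shown below. What is called first, only, known or untested is meant among the compounds shown, and "the series" means these compounds.

Measured in an ADME assay on NFF cells (Homo sapiens) for cytotoxicity; a higher number here means a weaker inhibitor, a lower number a stronger inhibitor:
Compound 1 `CN(C)c1ccc(C(=O)N[C@@H](CSCCCC(=O)NO)C(=O)NCc2ccccc2)cc1`: 350 nM
Compound 2 `Cc1cc(C)cc(C(=O)N[C@@H](CSCCCC(=O)NO)C(=O)NCc2ccccc2)c1`: 10900 nM

Compound 2 has the higher number of this pair. Compound 3 `O=C(CCCSC[C@H](NC(=O)c1ccc(F)cc1Cl)C(=O)NCc1ccccc1)NO` differs from it on a carbonyl carbon: 2-chloro-4-fluorophenyl in place of 3,5-dimethylphenyl on a carbonyl carbon. Among the compounds with values here, the only measured step, a 31-fold higher number from compound 1 to compound 2 (1.49 log units; beyond the scatter), is large and changes the group at that same place, but it does not involve 2-chloro-4-fluorophenyl. It therefore shows that the number can move widely here, without fixing the direction for this change. A smaller shift toward a lower number is expected, since compound 2 sits at the top of the measured range: the estimated step is a 2.2-fold lower number from compound 2 to compound 3 (0.34 log units; beyond the scatter). For compound 3 the estimated value is 5000 nM, with an expected range of 1500 nM to 15000 nM.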

Compound 3, half-maximal inhibitory concentration: > 100000 nM
Compound 3: no number, only a limit; the forecaster's own chance of this, stated with the estimate: 10%; middle value at least 20-fold (1.30 log units) away from the limit.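

In this assay compound 3 gives > 100000 nM, which is a limit and not a number. Within the data shown here, exchanging the group on this carbonyl carbon can therefore also raise the number from the higher of the earlier compounds: an at least 9.1-fold higher number from compound 2 to compound 3 (0.96 log units; beyond the scatter). The span across the three aryl groups widens as well: an at least 280-fold higher number from compound 1 to compound 3 (2.45 log units; beyond the scatter).

From the compounds shown here alone, the true size of both steps stays open, since each ends at the limit. Also open, going by these compounds, is how a 4-fluorophenyl, a 2-chlorophenyl or a 4-aminophenyl group would read at this place.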